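A few compounds are considered here, and "the series" means these few. Any claim that something is new, unique, unknown or untested is made for them only; others in the source may bear on it.

Measured so far:
compound 1, `CN1CCN(CCCOc2cccc3nc(Nc4ccc(Cl)c(F)c4)ccc23)CC1`: 1900 nM
compound 2, `CN1CCN(CCCOc2cccc3nc(Nc4ccc(F)c(F)c4)ccc23)CC1`: 2600 nM

In a functional assay on cells (Panel leukemia (Carcinoma cell lines), Homo sapiens) for inhibition, read by sulforhodamine B assay, with a stated time of 48 h (on this read-out lower numbers stand for stronger inhibition of growth and higher numbers for weaker inhibition of growth), compound 1 gives 1900 nM and compound 2 gives 2600 nM. For the measured compounds named here, compound 2 holds the higher of the two numbers, but the only measured step, a 1.4-fold higher number from compound 1 to compound 2 (0.14 log units; within the scatter), lies within the scatter, so the two compounds cannot be ranked against each other on these numbers.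

Compound 3, `CN1CCN(CCCOc2cccc3nc(Nc4cccc(Cl)c4)ccc23)CC1`, has not been measured. It differs from compound 2 in one place: 3-chlorophenyl in place of 3,4-difluorophenyl on a nitrogen on an aromatic ring. Going by the values given here, this change is not the same as the one in the measured step; the measured step exchanged a single halogen on the ring, whereas here one halogen is removed and the other is exchanged. The measured step of a 1.4-fold higher number from compound 1 to compound 2 (0.14 log units; within the scatter) shows that a halogen exchange on this ring left the number within the scatter, and nothing measured here points to a larger effect for compound 3.

Accordingly the step of a 1.1-fold lower number from compound 2 to compound 3 (0.05 log units; within the scatter) from compound 2 to compound 3 is expected to stay within the scatter. Compound 3 is estimated at 2300 nM, with a range from 900 nM to 6000 nM.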

Compound 3, concentration for 50% growth inhibition: 1990 nM
The estimate for compound 3 lay 1.2-fold (0.06 log units) above the measured number, and the stated range covers the measured number.
By their numbers in this assay, from the lowest: compounds 1, 3 and 2 (each within the scatter of the next).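

In this assay, 3-chlorophenyl in place of 3,4-difluorophenyl on a nitrogen on an aromatic ring gives a 1.3-fold lower number from compound 2 to compound 3 (0.12 log units; within the scatter), and the same group in place of 4-chloro-3-fluorophenyl gives a 1.0-fold higher number from compound 1 to compound 3 (0.02 log units; within the scatter), so neither step can be read as a change in growth inhibition. The earlier step exchanged only chloro for fluoro, whereas these two steps also alter how many halogens the phenyl group carries, and all three halogen patterns still stay within the scatter of each other on this read-out. Nothing available bears on why these numbers stay together.

The compounds shown carry only chloro- and fluoro-substituted phenyl groups on this nitrogen, so it remains open whether an unsubstituted phenyl, or a phenyl bearing a methoxy group, an amine or a carboxylic acid, would move the number beyond the scatter. The same question stands for the rest of the molecule, where a morpholine or a longer chain elsewhere on the shared core could show whether the growth inhibition of this series responds to changes outside the phenyl group.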